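The compounds below may be only part of what the source reports. "The series", "measured", "known", "first", "only" and "open" are said of these compounds alone.

Working notes on the series, read in a toxicity assay on HepG2 2.2.15 cells (Homo sapiens) for cytotoxicity, read by CellTiter-Glo; on this read-out lower numbers stand for higher toxicity in this test and higher numbers for lower toxicity in this test. Compound 1 `O=C1CC(c2cnc(C(F)(F)F)s2)CN1c1cnn2c1CN(C(=O)Nc1cc(F)c(F)c(F)c1)C(C1CC1)C2` gives 38500 nM, the highest number shown, and compound 2 `O=C1OC(c2ccc(F)cc2)CN1c1cnn2c1CN(C(=O)Nc1cc(F)c(F)c(F)c1)C(C1CC1)C2` sits lower at 3560 nM, a gap beyond the scatter. Compound 3 `C[C@H]1Cn2ncc(N3CC(c4ccccc4)CC3=O)c2CN1CC(=O)Nc1cc(F)c(F)c(F)c1` is reported only as a limit, > 2000 nM. Compound 4 `O=C1CC(c2ccc(F)cc2)CN1c1cnn2c1CN(C(=O)Nc1cc(F)c(F)c(F)c1)C(C1CC1)C2` is still unmeasured: it has 4-fluorophenyl in place of 2-(trifluoromethyl)-1,3-thiazol-5-yl on a saturated ring carbon. Going by the values given here, no measured step isolates this change. Among the compounds with values here, the only guide is compound 2, which also carries 4-fluorophenyl and gives 3560 nM. A step of a 4.3-fold lower number from compound 1 to compound 4 (0.63 log units; beyond the scatter) is therefore expected, towards a lower number and beyond the scatter. The estimate for compound 4 is 9000 nM, with an expected range from 2500 nM to 35000 nM.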

Compound 4, half-maximal cytotoxic concentration: 32100 nM
For compound 4 the middle estimate is 3.6-fold (0.55 log units) below the measured one; measured number inside the range.
By their numbers in this assay, from the lowest: compound 2; then compounds 4 and 1 (each within the scatter of the next).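

Exchange of 2-(trifluoromethyl)-1,3-thiazol-5-yl for 4-fluorophenyl gives a 1.2-fold lower number from compound 1 to compound 4 (0.08 log units; within the scatter) in this assay, so the read-out does not separate these two aromatic rings on this saturated ring carbon. The 4-fluorophenyl group alone does not bring a low number: compound 4 carries it, as does compound 2, which gives 3560 nM. The data on hand give no cause for this result.

Still open, going by these compounds, is whether an amine or a carboxylic acid on this ring carbon would leave the number unchanged in this assay.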